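The compounds below may be only part of what the source reports. "The series", "measured", "known", "first", "only" and "open" are said of these compounds alone.

In a functional assay on cells (Lymphocyte, Homo sapiens), read by trypan blue exclusion, with a stated time of 16 h, tested at 0.5 uM (a higher number here means a stronger effect of the compound at the concentration tested, a lower number a weaker effect), compound 2 `CCCCCCCCCCc1c(C)c(N(C)C)nc(C)c1O` gives 87%, the highest of the three numbers obtained so far. Compound 3 `CCCCCCCCCCc1nc(N(C)C)c(C)c(C)c1O` gives 77% in this assay, which lies within the usual scatter of such a result, so these two cannot be told apart. Compound 1 `CCCCCCCCCCCCCCCCc1c(C)c(N(C)C)nc(C)c1O` gives 56% in this assay, and its gap to compound 2 is beyond the scatter. The one change followed among these three is the length of the long chain: a number 31 percentage points higher from compound 1 to compound 2 (beyond the scatter).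

Compound 4 `CCCCCCCCCCCCCCCCCCCc1c(C)c(N(C)C)nc(C)c1O` has not yet been measured in this assay. It differs from compound 2 in a single place: nonyl in place of hydrogen on a saturated chain carbon, ten or more bonds along the chain from an aromatic carbon. Among the compounds with values here, the only measured step that bears on this is the one in which hydrogen stood in place of hexyl on the same chain, between compound 1 and compound 2, and that step was large. The step to compound 4 goes the other way, making the chain longer rather than shorter, and by a greater amount. On that ground a fall in this assay beyond the scatter is expected, a step of about a number 42 percentage points lower from compound 2 to compound 4 (beyond the scatter). For compound 4 the estimated result is 45%, with a likely range from 25% to 68%.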

Compound 4, a percentage reported as activity, at one concentration (the size of the read-out at that concentration, not a potency): 8%
For compound 4 the middle estimate is 37 percentage points above the measured one; the measured number lies below the stated range.
By their numbers in this assay, from the lowest: compound 4; then compound 1; then compounds 3 and 2 (each within the scatter of the next).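

The chain on this core does not merely tolerate change: in this assay the number keeps falling as the chain grows, with no levelling off among the lengths shown (a number 79 percentage points lower from compound 2 to compound 4 (beyond the scatter)). The fall also continues past compound 1, and adding only propyl at this place is already a large step (a number 48 percentage points lower from compound 1 to compound 4 (beyond the scatter)). Within the data shown here, one earlier step could show only that a longer chain did worse, whereas compounds 2, 1 and 4 now form a single downward series with no member against it, and at the far end compound 4 keeps little of the effect, at 8%. Nothing available here explains why the longer chains give lower numbers.

A shorter chain, such as hexyl, would show whether the number stays high or whether the series has an optimum near compound 2. On these data alone, it also remains open whether the same fall appears with longer chains on the core of compound 3, and whether a chain ending in a carboxylic acid or an amine follows the length alone.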